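The source may hold more compounds than are shown below. What is called first, only, known or untested is meant among the compounds shown, and "the series" means these compounds.

Measured compounds:
Compound 1, `Cc1ccc(C2CC(c3ccccc3)=NN2C(=O)c2cc3ccccc3o2)cc1`: 16.6 ug/mL
Compound 2, `COc1ccc(C2CC(c3ccccc3)=NN2C(=O)c2cc3ccccc3o2)cc1OC`: 6.89 ug/mL
Compound 3, `COc1ccc(C2CC(c3ccc(F)cc3)=NN2C(=O)c2cc3ccccc3o2)cc1OC`: > 50 ug/mL

In a functional assay on A2780 cells (Homo sapiens) for antiproliferative activity, read by MTT assay, with a stated time of 72 h (on this read-out higher numbers stand for weaker inhibition and lower numbers for stronger inhibition), compound 2 gives 6.89 ug/mL. Compound 1 differs from compound 2 by 4-methylphenyl in place of 3,4-dimethoxyphenyl on a saturated ring carbon, and this change gives a 2.4-fold higher number from compound 2 to compound 1 (0.38 log units; beyond the scatter). Compound 3 differs from compound 2 by fluoro in place of hydrogen on an aromatic carbon, and its reading is only a limit of the assay; compound 3 gives > 50 ug/mL. The step is then an at least 7.2-fold higher number from compound 2 to compound 3 (0.86 log units; beyond the scatter), resting on (the limit of > 50 ug/mL in this assay, at which 1 of the 3 values shown sits).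

Compound 4, `Cc1ccc(C2CC(c3ccc(F)cc3)=NN2C(=O)c2cc3ccccc3o2)cc1`, has not been measured. It differs from compound 3 by 4-methylphenyl in place of 3,4-dimethoxyphenyl on a saturated ring carbon. For the measured compounds named here, this is the same kind of change as the one from compound 2 to compound 1, but not the same: around the place, compound 3 carries a 4-fluorophenyl group (7 heavy atoms) where compound 2 carries a phenyl group (6 heavy atoms), and the neighbouring ring atom is described as bearing a (1-benzofuran-2-yl)carbonyl group rather than simply a large group.

The expectation for compound 4 rests on the earlier step, which made a higher number from compound 2 to compound 1, and on compound 3 already sitting at > 50 ug/mL. Compound 4 is therefore expected to show a step that the limit leaves unreadable from compound 3 to compound 4, so that compound 4 is estimated at 90 ug/mL, between 35 ug/mL and 250 ug/mL, with a good chance that the assay again reports only a limit.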

Compound 4, half-maximal inhibitory concentration: > 50 ug/mL
Compound 4: no number, only a limit (the forecaster's own chance of this, stated with the estimate: 70%); the middle value is on the limit's open side.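

In this assay compound 4 gives > 50 ug/mL, which is a limit of the assay and not a number. Fluoro in place of hydrogen on an aromatic carbon gives an at least 3.0-fold higher number from compound 1 to compound 4 (0.47 log units; beyond the scatter), so the weaker inhibition seen on the core of compound 2 also appears on the core of compound 1, and the direction of this change carries from one core to the other in these two pairs: the same change on two cores in this assay, an at least 7.2-fold higher number (0.86 log units; beyond the scatter) from compound 2 to compound 3 and an at least 3.0-fold higher number (0.47 log units; beyond the scatter) from compound 1 to compound 4; the limit leaves it open whether they differ What this does not show is whether the size of the change carries over, and the step from compound 3 to compound 4 cannot be read at all, so nothing can be said about 4-methylphenyl in place of 3,4-dimethoxyphenyl once the fluoro is present: the limit of > 50 ug/mL in this assay, at which 2 of the 4 values shown sit.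

As far as these compounds go, it remains open how far beyond the limit compound 3 and compound 4 lie, and so whether the 3,4-dimethoxyphenyl group keeps any advantage over 4-methylphenyl on the fluoro core. From the compounds shown here alone, it is also open whether a chloro or a hydroxy group in place of the fluoro would shift the number in the same direction on either core.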